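Isopropyl Replaces an Ester Arm: Tolerance Outlook

A few compounds are considered here, and "the series" means these few. Any claim that something is new, unique, unknown or untested is made for them only; others in the source may bear on it.

Three compounds have been measured in an ADME assay on Huh-7 cells (Homo sapiens) for cytotoxicity; a higher number here means that more compound is tolerated, a lower number that less compound is tolerated:

Compound 1 `CN1CCN(CCCNCc2cn(-c3ccc([N+](=O)[O-])cc3)nc2-c2ccc(C(F)(F)F)cc2)CC1`: 4900 nM
Compound 2 `CCOC(=O)Cn1cc(CNCCN2CCN(C)CC2)c(-c2ccccc2C)n1`: > 20000 nM
Compound 3 `CN1CCN(CCNCc2cn(-c3ccc(C(F)(F)F)cc3)nc2-c2ccc(Cl)cc2)CC1`: 3000 nM

Compound 2 stands apart from the other two: its result in this assay is a limit rather than a number, (the limit of > 20000 nM in this assay, at which 1 of the 3 values shown sits). Compound 1 and compound 3 both give numbers in a similar range. Compound 4 `Cc1ccccc1-c1nn(C(C)C)cc1CNCCN1CCN(C)CC1` differs from compound 2 in a single place, (isopropyl in place of (ethoxycarbonyl)methyl on an aromatic nitrogen). Going by the values given here, no measured pair differs at only one site, so the size of such a step has not been tested here. The step of a number no higher from compound 2 to compound 4 (the limit leaves the size open) in this assay is expected to be small, with no clear direction. Compound 4 is therefore estimated at 20000 nM, spanning 8000 nM to 40000 nM, and it may well return only a limit once more.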

Compound 4, half-maximal cytotoxic concentration: > 20000 nM
Compound 4: no number, only a limit; the forecaster's own chance of this, stated with the estimate: 55%; the middle value sits exactly at the limit.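

Compound 2 and compound 4 each return only a limit in this assay, and the step between them cannot be read. The compounds shown leave open what size, or direction, putting isopropyl in place of (ethoxycarbonyl)methyl has.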